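This account rests on a few compounds, and the source may have more. Where it says the series, first, only, none or still open, it means among the compounds named here.

Measured compounds:
- compound 1 `COC(=O)[C@@H]1C[C@@]2(CC=C(C)C)c3ccccc3N3C(=N)[C@H](Cc4ccccc4)N1[C@H]32`; in a functional assay on MDA-MB-231 cells (Homo sapiens) for cytotoxicity, read by sulforhodamine B assay, with a stated time of 48 h (on this read-out higher numbers stand for weaker inhibition of growth and lower numbers for stronger inhibition of growth), compound 1 gives > 100000 nM, a limit of the assay and not a number.
- compound 2 `COC(=O)[C@@H]1C[C@@]2(CC=C(C)C)c3ccccc3N3C(=N)[C@H](c4ccccc4)N1[C@H]32`; in this assay compound 2 gives > 100000 nM, again a limit of the assay.

Compound 1 therefore stands at the limit: it shows no growth inhibition that the assay could put a number on, and the same holds for compound 2, so that the limit of > 100000 nM in this assay, at which 2 of the 2 values shown sit, describes every value shown. Going by the values given here, the only step between measured compounds, a step that the two limits leave unreadable from compound 1 to compound 2, replaces a benzyl by a phenyl on a saturated ring carbon, and since both ends sit at the limit its size cannot be read.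

Compound 3 `COC(=O)[C@@H]1C[C@]2(CC=C(C)C)c3ccccc3N3C(=N)[C@@H](Cc4ccccc4)N1[C@@H]32` differs from compound 1 by the two compounds have the same atoms and bonds; at least one stereo element is drawn with a configuration in one of them and without one in the other: 3 of 5 stereo elements differ; a stereocentre at a saturated ring carbon is drawn S in compound 1 and R in compound 3; a stereocentre at a saturated ring carbon is drawn S in compound 1 and R in compound 3; a stereocentre at a saturated ring carbon is drawn R in compound 1 and S in compound 3. No measured step concerns a change of configuration, and the single step shown is unreadable, so nothing in these data suggests that compound 3 should move away from the limit where compound 1 sits. Compound 3 is therefore expected in this assay at about 100000 nM, with a range of 30000 nM to 300000 nM. The step of a number no higher from compound 1 to compound 3 (the limit leaves the size open) is expected to be no larger than the scatter.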

Compound 3, concentration for total growth inhibition: 24100 nM
The estimate for compound 3 lay 4.1-fold (0.62 log units) above the measured number; measured number outside the range, below it.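

Going by these compounds alone, compound 3 is the first compound here to give a number rather than a limit in this assay, and it has the same atoms and bonds as compound 1, so only the drawn configuration separates the two. The change at three stereocentres on saturated ring carbons gives an at least 4.1-fold lower number from compound 1 to compound 3 (0.61 log units; beyond the scatter), which shows that configuration in the shared core bears on this read-out, something the unreadable replacement of benzyl by phenyl could not show, and the size stays open at one end: the limit of > 100000 nM in this assay, at which 2 of the 3 values shown sit. The comparison also carries a caution about how the two structures are drawn: the fact that one of compounds 1 and 3 is drawn with a defined configuration and the other without, at the place where they differ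

Which of the three stereocentres carries the step stays open, as does whether phenyl in place of benzyl would give a readable step in the configuration of compound 3. The compounds shown also leave open how an amine or a longer chain in place of the benzyl, or a carboxylic acid in place of the methyl ester, would read in this assay.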